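Replacing pyridin-2-yl on the shared core

A few compounds are considered here, and "the series" means these few. Any claim that something is new, unique, unknown or untested is made for them only; others in the source may bear on it.

Measured in a physicochemical assay for solubility, in phosphate buffer, at pH 7.4 (a higher number here means a more soluble compound, a lower number a less soluble compound), so far:
- compound 1 `NC(=O)C1CCN(c2nccnc2OC2CN(c3ccc4ccccc4n3)C2)CC1` gives 14000 nM
- compound 2 `OCc1cccc(-c2nccnc2OC2CN(c3ccc4ccccc4n3)C2)c1` gives 29000 nM
- compound 3 `c1ccc(-c2nccnc2OC2CN(c3ccc4ccccc4n3)C2)nc1` gives 349000 nM

Compound 3 stands highest of these, and its gaps to both others lie beyond the scatter. Compound 4 `COC(=O)N1CCC(c2nccnc2OC2CN(c3ccc4ccccc4n3)C2)CC1` has not yet been measured. It differs from compound 3 by one exchange on an aromatic carbon (1-(methoxycarbonyl)piperidin-4-yl in place of pyridin-2-yl on an aromatic carbon).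

Going by the values given here, two measured steps bear on this exchange: a 25-fold higher number from compound 1 to compound 3 (1.40 log units; beyond the scatter) when pyridin-2-yl replaces 4-carbamoylpiperidin-1-yl, and a 12-fold higher number from compound 2 to compound 3 (1.08 log units; beyond the scatter) when it replaces 3-(hydroxymethyl)phenyl. Both are large. Compound 4 gives up pyridin-2-yl too, and its new group contains a piperidine ring, as does the group in compound 1 (14000 nM). Among the compounds with values here, a large drop in this assay is therefore expected, though no measured compound carries the new group itself. The estimate is a 17-fold lower number from compound 3 to compound 4 (1.24 log units; beyond the scatter) as the expected change. For compound 4 the estimated value is 20000 nM with an expected range from 5000 nM to 80000 nM as its limits.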

Compound 4, solubility: 138000 nM
The estimate for compound 4 lay 6.9-fold (0.84 log units) below the measured number, outside the stated range (above it).
By their numbers in this assay, from the lowest: compound 1; then compound 2; then compound 4; then compound 3.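

In this assay, a non-aromatic ring at this position does not bring a large drop from the pyridin-2-yl compound: the exchange gives a 2.5-fold lower number from compound 3 to compound 4 (0.40 log units; beyond the scatter) and no more. An aromatic ring here does not always give the higher number either, since compound 3 stands above compound 4 while 3-(hydroxymethyl)phenyl goes against that order, with a 4.8-fold higher number from compound 2 to compound 4 (0.68 log units; beyond the scatter) on exchange for 1-(methoxycarbonyl)piperidin-4-yl. Holding a piperidine ring does not fix the number, as a 9.9-fold higher number from compound 1 to compound 4 (0.99 log units; beyond the scatter) separates two piperidine-bearing groups, and nothing measured here gives a reason for any of these differences.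

Compound 1 and compound 4 differ both in how the piperidine ring is attached and in what it carries, so these two changes cannot be told apart. On these data alone, how a piperidin-4-yl with a free amine, or a morpholine ring, would behave at this position remains open.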